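A bromine shifted around one ring, potency weighed

The compounds below may be only part of what the source reports. "The series", "measured", "known", "first", "only" and "open" are said of these compounds alone.

Compound 1, `C/C(=N\NC(=O)/C(C#N)=C/c1ccccc1)c1c(O)c2ccc(O)cc2oc1=O`, gives 15800 nM in a functional assay on HeLa cells (Homo sapiens) for cytotoxicity, read by MTT assay, with a stated time of 24 h; on this read-out lower numbers stand for stronger inhibition and higher numbers for weaker inhibition.
Compound 2, `C/C(=N\NC(=O)/C(C#N)=C/c1ccc(O)cc1)c1c(O)c2ccc(O)cc2oc1=O`, gives 6020 nM in this assay.
Compound 3, `C/C(=N\NC(=O)/C(C#N)=C/c1ccc(Br)cc1)c1c(O)c2ccc(O)cc2oc1=O`, gives 10600 nM in this assay.

All three share the same core and differ only in one substituent on the pendant aromatic ring. The number for compound 3 lies between those of its two neighbours, but both a 1.5-fold lower number from compound 1 to compound 3 (0.17 log units; within the scatter) and a 1.8-fold higher number from compound 2 to compound 3 (0.25 log units; within the scatter) fall within the scatter of repeated measurement, so no firm order among compounds 1, 2 and 3 can be claimed. For the measured compounds named here, the only step beyond the scatter is a 2.6-fold lower number from compound 1 to compound 2 (0.42 log units; beyond the scatter).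

Compound 4, `C/C(=N\NC(=O)/C(C#N)=C/c1cccc(Br)c1)c1c(O)c2ccc(O)cc2oc1=O`, is not yet measured. It differs from compound 3 by 3-bromophenyl in place of 4-bromophenyl on a double-bonded chain carbon bound to a double-bonded chain carbon. Going by the values given here, no measured pair moves a group from one place on that ring to another; the steps that involve the bromine, a 1.5-fold lower number from compound 1 to compound 3 (0.17 log units; within the scatter) and a 1.8-fold higher number from compound 2 to compound 3 (0.25 log units; within the scatter), add or swap it and stay within the scatter. With nothing pointing to a shift either way, the expected step is none beyond the scatter.

The estimated step from compound 3 is a 1.1-fold lower number from compound 3 to compound 4 (0.03 log units; within the scatter). Compound 4 is therefore expected to give about 10000 nM in this assay, within a range from 4000 nM to 25000 nM.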

Compound 4, half-maximal inhibitory concentration: 24300 nM
For compound 4 the middle estimate is 2.4-fold (0.39 log units) below the measured one; the range from low to high includes it.
By their numbers in this assay, from the lowest: compounds 2, 3, 1 and 4 (each within the scatter of the next, the first and the last beyond it).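

In this assay, for the compounds shown here, the same atoms joined differently give a readable change for the first time: 3-bromophenyl in place of 4-bromophenyl gives a 2.3-fold higher number from compound 3 to compound 4 (0.36 log units; beyond the scatter) and so shows that the place of the bromine on this ring counts, which the earlier steps that only added or swapped a bromine could not show. Against the 4-hydroxyphenyl compound the same group gives a 4.0-fold higher number from compound 2 to compound 4 (0.61 log units; beyond the scatter) as the largest step in the set, while a 1.5-fold higher number from compound 1 to compound 4 (0.19 log units; within the scatter) means that 3-bromophenyl cannot be told apart from plain phenyl here. Nothing measured in this set offers a reason for these steps.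

On these data alone, whether the place on the ring matters for other groups stays open, since 3-hydroxyphenyl would test whether the hydroxy group follows the same pattern as the bromine, and an amine or a carboxylic acid on the ring would show how far the pattern reaches. All of these numbers also come from one cell line at one stated time, so they cannot say whether the same order would hold in other cells.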